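Swapping one ring on a weakly active amide

The source may report more compounds than this note shows. Statements on the series, on what has been measured and on what is new or still open speak of the compounds shown alone.

Compound 1 `O=C(Nc1ccc(-c2cscn2)cc1)C1CCN(Cc2ccc(F)c(F)c2)C1` – 8000 nM
Compound 2 `O=C(Nc1ccc(-c2c[nH]cn2)cc1)C1CCCN(Cc2ccc(F)c(F)c2)C1` – 16000 nM

Both values come from a functional assay on A-375 cells (Homo sapiens) for activation, with a stated time of 3 days (on this read-out lower numbers stand for an effect already at smaller amounts and higher numbers for an effect only at larger amounts of compound), and only these two compounds have been measured so far. Compound 2 (16000 nM) lies within the usual scatter of compound 1 (8000 nM), so the two cannot be told apart, even though they differ in more than one place.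

The next compound, compound 3 `O=C(Nc1ccc(-c2ccc[nH]2)cc1)C1CCCN(Cc2ccc(F)c(F)c2)C1`, carries 1H-pyrrol-2-yl in place of 1H-imidazol-4-yl on an aromatic carbon and is otherwise identical to compound 2.

Among the measured compounds shown here, no measured pair shows this change, so any step in this assay can only be estimated. A modest expected move toward lower numbers, possibly none beyond the scatter, seems most likely (a 2.0-fold lower number from compound 2 to compound 3 (0.30 log units; within the scatter)). For compound 3 the estimated value is 8000 nM (expected range 2500 nM to 25000 nM).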

Compound 3, half-maximal effective concentration: 720 nM
Estimate against measurement, compound 3: 11-fold (1.05 log units) above, and the stated range ends above it.
By their numbers in this assay, from the lowest: compound 3; then compounds 1 and 2 (each within the scatter of the next).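

This position clearly matters in this assay: with the rest of the molecule unchanged, 1H-pyrrol-2-yl in place of 1H-imidazol-4-yl brings a large step (a 22-fold lower number from compound 2 to compound 3 (1.35 log units; beyond the scatter)), something the earlier pair, which differs in more than one place, could not show. Both rings are five-membered and aromatic and each carries a hydrogen-bond donor, so the counted differences are one ring nitrogen replaced by carbon and one hydrogen-bond acceptor fewer. No measurement here explains why the read-out moves so far.

Going by these compounds, it remains open whether the same swap would give a similar step on the core of compound 1. On these data alone, how a furan-2-yl ring, a plain phenyl ring or an amine at this position would compare also remains unknown.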